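The compounds below may be only part of what the source reports. "The series", "measured", "known", "first", "only" and "open" are said of these compounds alone.

In a physicochemical assay for solubility, with a stated time of 3 days, at pH 7 (a lower number here means a less soluble compound, a higher number a more soluble compound), compound 1 `NC(=O)c1ccc2[nH]c(-c3ccc(OC4CCNCC4)cc3)nc2c1` stands as "not determined" (no result reported) and so offers nothing to compare. Among the compounds with values here, compound 2 `NC(=O)c1ccc2[nH]c(-c3ccc(OCCC4CCCCN4Cc4ccccc4)cc3)nc2c1` gives 155000 nM as the only number so far, so it cannot yet be ranked as high or low within this small set. Compound 3 `Cc1ccc(CN2CCCCC2CCOc2ccc(-c3nc4cc(C(N)=O)ccc4[nH]3)cc2)cc1` has not been measured. It differs from compound 2 by one small change methyl in place of hydrogen on an aromatic carbon that turns benzyl to 4-methylbenzyl, with methyl in place of hydrogen on an aromatic carbon. Within the data shown here, no measured pair here shows what such a change does, so only a general expectation is possible: a modest fall, perhaps no larger than the usual scatter of repeat measurements. The expected step of a 1.4-fold lower number from compound 2 to compound 3 (0.15 log units; within the scatter) is therefore small and downward. For compound 3 the estimate is 110000 nM with an expected range from 45000 nM to 220000 nM in this assay once it is measured.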

Compound 3, solubility: 97000 nM
Compound 3: middle estimate off by 1.1-fold (0.05 log units), on the high side; the range from low to high includes it.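

In this assay, within the data shown here, the methyl on the aromatic carbon of the benzyl group gives a 1.6-fold lower number from compound 2 to compound 3 (0.20 log units; within the scatter) and provides the first measured pair in this set that differs in one place. Compound 2 and compound 3 therefore cannot be told apart in this read-out, so turning benzyl to 4-methylbenzyl has no effect here that stands clear of repeat measurements. Nothing in the data shown accounts for this result.

On these data alone, it remains open whether a different group on the same aromatic carbon, such as an amine, a carboxylic acid or a longer carbon chain, would give a step beyond the scatter. A single pair with a single methyl also cannot show how other changes to the benzyl group would behave, so no general trend for this position can be drawn from it.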